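The compounds below may be only part of what the source reports. "The series", "measured", "known", "first", "only" and "open" are said of these compounds alone.

Measured so far in a functional assay on A549 cells (Homo sapiens) for inhibition, read by MTT assay, with a stated time of 48 h; on this read-out lower numbers stand for stronger inhibition and higher numbers for weaker inhibition:

Compound 1 `O=[N+]([O-])c1ccc2[nH]cc(C(c3ccc(Br)cc3)c3c[nH]c4ccc([N+](=O)[O-])cc34)c2c1`: the value > 100000 nM is a limit of this assay, not a number.
Compound 2 `O=[N+]([O-])c1ccc(C(c2c[nH]c3ccc([N+](=O)[O-])cc23)c2c[nH]c3ccc([N+](=O)[O-])cc23)cc1`: the value > 100000 nM is also a limit.
Compound 3 `OC[C@H]1O[C@@H](n2cc(C(c3ccc(Br)cc3)c3cn([C@@H]4O[C@H](CO)[C@@H](O)[C@H](O)[C@H]4O)c4ccc(Br)cc34)c3cc(Br)ccc32)[C@H](O)[C@@H](O)[C@@H]1O`: 2500 nM.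

Compounds 1 and 2 differ in one place, and the change from compound 1 to compound 2, (nitro in place of bromo on an aromatic carbon), gives the step that the two limits leave unreadable from compound 1 to compound 2. Its size cannot be read because of the limit of > 100000 nM in this assay, at which 2 of the 3 values shown sit. Compound 3 carries a different core; how the core of compound 1 and the core of compound 3 differ is not broken down here. Compound 4 `O=[N+]([O-])c1ccc(C(c2cn([C@@H]3O[C@H](CO)[C@@H](O)[C@H](O)[C@H]3O)c3ccc(Br)cc23)c2cn([C@@H]3O[C@H](CO)[C@@H](O)[C@H](O)[C@H]3O)c3ccc(Br)cc23)cc1` has not yet been measured in this assay. It differs from compound 3 by nitro in place of bromo on an aromatic carbon, which is the same change, at the same place, as that from compound 1 to compound 2. Among the measured compounds shown here, since the earlier step gives no readable size, the expectation for compound 4 rests on compound 3 alone, whose value 2500 nM is the only number seen. The step of a 1.2-fold higher number from compound 3 to compound 4 (0.08 log units; within the scatter) is therefore expected to be small. Compound 4 is estimated at 3000 nM in this assay, most likely between 900 nM and 15000 nM.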

Compound 4, half-maximal inhibitory concentration: 2400 nM
Compound 4: the middle estimate sits 1.3-fold (0.10 log units) above what was measured; the range from low to high includes it.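

In this assay, putting nitro in place of bromo on the core of compound 3 gives a 1.0-fold lower number from compound 3 to compound 4 (0.02 log units; within the scatter), so on this core the 4-bromophenyl and 4-nitrophenyl compounds cannot be told apart. The same change on the core of compound 1 gives a step that cannot be read, because compound 1 and compound 2 both stand at a limit of the assay and not at a number: the limit of > 100000 nM in this assay, at which 2 of the 4 values shown sit. The series therefore offers only one readable size for this change, which shows what it does on one core but not whether that size carries over to the other.

On these data alone, it remains open whether an amine or a carboxylic acid in place of the nitro would shift the number on the core of compound 3, given that bromo and nitro read alike there. As far as these compounds go, it is equally open how a longer chain in that place would read on either core.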